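Swapping an aromatic ring for a saturated one on the core

This account rests on a few compounds, and the source may have more. Where it says the series, first, only, none or still open, it means among the compounds named here.

Compound 1 `O=c1cc(-c2ccccc2)oc2ccc(OCCCCCCN3CCCC(O)C3)cc12`: 77 nM
Compound 2 `O=c1cc(-c2ccccc2)oc2ccc(OCCCCCCN3CCNCC3c3ncccn3)cc12`: 14200 nM
Compound 3 `O=c1cc(-c2cccnc2)oc2ccc(OCCCCCCN3CCC(O)CC3)cc12`: 210 nM

In an assay on isolated protein (Cavia porcellus) with Sigma non-opioid intracellular receptor 1 (Homo sapiens) as the target, read by radioligand binding (on this read-out lower numbers stand for stronger inhibition and higher numbers for weaker inhibition), compound 3 gives 210 nM, the second highest of the three numbers: compound 1 shows a lower number and compound 2 a far higher one. Among the measured compounds shown here, the only step measured so far, a 180-fold higher number from compound 1 to compound 2 (2.27 log units; beyond the scatter), alters a different part of the molecule than the group on the core, so it does not bear directly on the change considered here. Compound 4 `O=c1cc(C2CCCC2)oc2ccc(OCCCCCCN3CCC(O)CC3)cc12` carries cyclopentyl in place of pyridin-3-yl on an aromatic carbon. Without a measured step at that position, the direction is open; a change of at most modest size is expected, a 1.3-fold lower number from compound 3 to compound 4 (0.12 log units; within the scatter). Compound 4 is therefore estimated at 160 nM, with a range from 40 nM to 650 nM.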

Compound 4, half-maximal inhibitory concentration: 55 nM
Compound 4: middle estimate off by 2.9-fold (0.46 log units), on the high side; the measured number falls inside the stated range.
By their numbers in this assay, from the lowest: compounds 4 and 1 (each within the scatter of the next); then compound 3; then compound 2.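

Cyclopentyl in place of pyridin-3-yl on this aromatic carbon next to the ring oxygen gives a 3.8-fold lower number from compound 3 to compound 4 (0.58 log units; beyond the scatter) in this assay. At this position, then, neither an aromatic ring nor the ring nitrogen with its hydrogen-bond acceptor is needed for a low number, at least in this pair. No measurement here explains the shift.

Going by these compounds, the step changes aromaticity, ring size and the nitrogen all at once, so their separate shares remain open. On these data alone, whether cyclohexyl or an open-chain tert-butyl group would serve equally well also remains open.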